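The compounds below may be only part of what the source reports. "The series", "measured", "known", "first", "only" and "open" are said of these compounds alone.

Compound 1 `COc1ccc(-c2nc3cccc(-c4cc(OC)c(OC)c(OC)c4)c3o2)cc1OC`: 2800 nM
Compound 2 `COc1cc(-c2cccc3nc(-c4cccc(Cl)c4)oc23)cc(OC)c1OC`: > 25000 nM (a limit)
Compound 3 `COc1cc(-c2cccc3nc(-c4ccc(Cl)cc4)oc23)cc(OC)c1OC`: 5600 nM

In a functional assay on A549 cells (Homo sapiens) for antiproliferative activity, read by MTT assay, with a stated time of 48 h (a higher number here means a weaker inhibitor, a lower number a stronger inhibitor), compound 3 gives 5600 nM. It cannot be told apart from compound 1, as a 2.0-fold higher number from compound 1 to compound 3 (0.30 log units; within the scatter) shows. Compound 2 gives > 25000 nM, which is a limit of the assay and not a number.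

Compound 4 `COc1cc(-c2cccc3nc(-c4cccc(O)c4)oc23)cc(OC)c1OC` places 3-hydroxyphenyl where compound 3 has 4-chlorophenyl: 3-hydroxyphenyl in place of 4-chlorophenyl on an aromatic carbon. For the measured compounds named here, no measured compound carries 3-hydroxyphenyl, so the nearest guide is compound 2, which carries 3-chlorophenyl. Going by the values given here, two measured steps bear on this: an at least 4.4-fold lower number from compound 2 to compound 3 (0.64 log units; beyond the scatter), and an at least 8.9-fold higher number from compound 1 to compound 2 (0.95 log units; beyond the scatter). Both suggest that a lone group named at the 3-position of this phenyl ring may do poorly, although chlorine and hydroxyl are different groups and the evidence is a single compound. A modest loss of activity in this assay is therefore expected, with a real chance that only a limit is reported. The expected change is a 2.1-fold higher number from compound 3 to compound 4 (0.33 log units; beyond the scatter). For compound 4 the estimated value is 12000 nM, with an expected range from 4000 nM to 25000 nM.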

Compound 4, half-maximal inhibitory concentration: 2000 nM
For compound 4 the middle estimate is 6.0-fold (0.78 log units) above the measured one, and the stated range ends above it.
By their numbers in this assay, from the lowest: compounds 4, 1 and 3 (each within the scatter of the next, the first and the last beyond it). At a limit, above all of these: compound 2.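

In this assay, hydroxy in place of chloro gives an at least 12-fold lower number from compound 2 to compound 4 (1.09 log units; beyond the scatter), so the poor result of 3-chlorophenyl comes with that group and not with every group placed as it is on this phenyl ring. Compound 2 stands at a limit, not a number: the limit of > 25000 nM in this assay, at which 1 of the 4 values shown sits. The 3-hydroxyphenyl group also does better than 4-chlorophenyl, with a 2.8-fold lower number from compound 3 to compound 4 (0.45 log units; beyond the scatter), while a 1.4-fold lower number from compound 1 to compound 4 (0.15 log units; within the scatter) shows that it cannot be told apart from 3,4-dimethoxyphenyl.

The compounds shown leave open whether a free hydroxy is needed, since 3-aminophenyl or 3-methoxyphenyl would test other groups in its place, and whether 4-hydroxyphenyl would do as well. Nor do they tell why hydroxy and chloro differ so widely here.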